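Swapping the nitro group for a methyl on the aryl ring

The source may report more compounds than this note shows. Statements on the series, on what has been measured and on what is new or still open speak of the compounds shown alone.

Of the compounds shown here, two have been measured in a functional assay on PC-3 cells (Homo sapiens) for cytotoxicity, read by MTT assay, with a stated time of 72 h; on this read-out lower numbers stand for stronger inhibition and higher numbers for weaker inhibition. Compound 1 `CC1=C(/C=C/C(=O)/C=C/c2cccc(F)c2)C(C)(C)CCC1` gives 18700 nM in this assay. Compound 2 `CC1=C(/C=C/C(=O)/C=C/c2cccc([N+](=O)[O-])c2)C(C)(C)CCC1` gives 10000 nM in this assay. Of the two numbers, compound 2 has the lower one, but the change from a 1.9-fold lower number from compound 1 to compound 2 (0.27 log units; within the scatter) is within the scatter, so the two compounds cannot be told apart on this read-out.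

Compound 3 `CC1=C(/C=C/C(=O)/C=C/c2cccc(C)c2)C(C)(C)CCC1` is not yet measured. It differs from compound 2 in one place: methyl in place of nitro on an aromatic carbon. For the measured compounds named here, the only measured step, which exchanged one aromatic substituent for another, moved the number from a 1.9-fold lower number from compound 1 to compound 2 (0.27 log units; within the scatter), a shift that lies within the scatter. Going by the values given here, no measured step involves a methyl, and the nitro-to-methyl exchange itself has not been seen in this set, so there is nothing to suggest a shift beyond the scatter in this assay.

On that basis, compound 3 is expected to give about 14000 nM in this assay, most likely between 6000 nM and 35000 nM, which means an estimated step of a 1.4-fold higher number from compound 2 to compound 3 (0.15 log units; within the scatter) from compound 2.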

Compound 3, half-maximal inhibitory concentration: 35000 nM
Estimate against measurement, compound 3: 2.5-fold (0.40 log units) below, within the range that was stated.
By their numbers in this assay, from the lowest: compounds 2, 1 and 3 (each within the scatter of the next, the first and the last beyond it).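

For the compounds shown here, at this place on the aromatic ring, the exchange of nitro for methyl gives the first step in this assay that clears the usual scatter, with a 3.5-fold higher number from compound 2 to compound 3 (0.54 log units; beyond the scatter) as a modest but readable change, so the choice of group here can register on this read-out. The fluoro compound does not separate from either of the others: with a 1.9-fold higher number from compound 1 to compound 3 (0.27 log units; within the scatter) and the earlier 1.9-fold lower number from compound 1 to compound 2 (0.27 log units; within the scatter) both inside the scatter, compound 1 cannot be told apart from compound 2 or compound 3, and only the nitro and methyl compounds can be told apart from each other. Nothing available explains what in this exchange produces the step.

From the compounds shown here alone, these three compounds differ at a single place on the ring, so it remains open whether an amine, a carboxylic acid or a methoxy group there would give a number close to that of compound 2, close to that of compound 3, or far from both. Going by these compounds, it also remains open whether the same exchange of nitro for methyl would produce a step of similar size at another carbon of the ring or on a different cell line.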